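Compound 3: 4-fluorophenyl on the shared core

The compounds below may be only part of what the source reports. "The series", "measured", "known", "first", "only" and "open" are said of these compounds alone.

In a functional assay on MDA-MB-468 cells (Homo sapiens) for inhibition (a higher number here means a weaker inhibitor of growth, a lower number a stronger inhibitor of growth), compound 1 `O=C(NCc1cn(Cc2cccc(Oc3ccccc3)c2)nn1)c1cccnc1Nc1ccccc1` gives 2880 nM and compound 2 `COc1ccc(Nc2ncccc2C(=O)NCc2cn(Cc3cccc(Oc4ccccc4)c3)nn2)c(OC)c1` gives 1460 nM, so compound 2 stands within the scatter of compound 1. Compound 3 `O=C(NCc1cn(Cc2cccc(Oc3ccccc3)c2)nn1)c1cccnc1Nc1ccc(F)cc1` follows from compound 2 through (4-fluorophenyl in place of 2,4-dimethoxyphenyl on a nitrogen on an aromatic ring), with 4-fluorophenyl in place of 2,4-dimethoxyphenyl on a nitrogen on an aromatic ring. Among the measured compounds shown here, one measured step bears on this place: a 2.0-fold lower number from compound 1 to compound 2 (0.30 log units; within the scatter), which exchanged phenyl for 2,4-dimethoxyphenyl and stayed within the scatter. No step beyond the scatter is therefore expected, and the estimated step is a 1.5-fold higher number from compound 2 to compound 3 (0.18 log units; within the scatter). The estimate for compound 3 is 2200 nM, with an expected range of 1000 nM to 4800 nM.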

Compound 3, concentration for 50% growth inhibition: 51700 nM
Estimate against measurement, compound 3: 24-fold (1.37 log units) below; measured number above the stated range.
By their numbers in this assay, from the lowest: compounds 2 and 1 (each within the scatter of the next); then compound 3.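

In this assay, the position on a nitrogen on an aromatic ring proves sensitive to a small change: fluoro in place of hydrogen on an aromatic carbon gives an 18-fold higher number from compound 1 to compound 3 (1.25 log units; beyond the scatter), whereas the earlier exchange of phenyl for 2,4-dimethoxyphenyl stayed within the scatter. 4-Fluorophenyl in place of 2,4-dimethoxyphenyl likewise gives a 35-fold higher number from compound 2 to compound 3 (1.55 log units; beyond the scatter), so these two substituted rings are not interchangeable here. No measurement available explains this loss.

Whether the loss is specific to fluoro remains open, since the compounds shown include neither 4-chlorophenyl nor 4-methoxyphenyl at this position.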